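Replacing cyclobutyl with 4-methylphenyl on the amide carbonyl

The compounds below may be only part of what the source reports. "The series", "measured", "known", "first", "only" and "open" are said of these compounds alone.

Three compounds share one core and differ only in the group on the carbonyl carbon of the amide. Compound 1 `CCC(CC)C(=O)Nc1c(C(O)(C(F)(F)F)C(F)(F)F)ccc2ccccc12` gives 4340 nM in an assay on LtK cells with ATP-sensitive inward rectifier potassium channel 11 (Homo sapiens) as the target; a higher number here means that more compound is needed for the effect, a lower number that less compound is needed. Compound 2 `O=C(Nc1c(C(O)(C(F)(F)F)C(F)(F)F)ccc2ccccc12)C1CCC1` gives 45 nM, and compound 3 `O=C(Nc1c(C(O)(C(F)(F)F)C(F)(F)F)ccc2ccccc12)c1ccccc1` gives 44 nM. Compound 2 thus stands second highest of the three numbers: its nearest neighbour is compound 3, a difference within the scatter, and its furthest is compound 1, where a 96-fold lower number from compound 1 to compound 2 (1.98 log units; beyond the scatter) was observed.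

Compound 4 `Cc1ccc(C(=O)Nc2c(C(O)(C(F)(F)F)C(F)(F)F)ccc3ccccc23)cc1` has not yet been measured. It differs from compound 2 as follows: 4-methylphenyl in place of cyclobutyl on a carbonyl carbon. The step that bears most directly on this change is the one from cyclobutyl to phenyl, a 1.0-fold lower number from compound 2 to compound 3 (0.01 log units; within the scatter), which stayed within the scatter; both large steps, a 96-fold lower number from compound 1 to compound 2 (1.98 log units; beyond the scatter) and a 99-fold lower number from compound 1 to compound 3 (1.99 log units; beyond the scatter), involve leaving pentan-3-yl and are not at issue here. Since compound 3 already carries phenyl at this position and gives 44 nM, no step beyond the scatter is expected. Compound 4 is therefore estimated at 45 nM, within a range of 15 nM to 140 nM, corresponding to an expected step of no change at the digits printed from compound 2 to compound 4 (within the scatter).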

Compound 4, half-maximal effective concentration: 76 nM
For compound 4 the middle estimate is 1.7-fold (0.23 log units) below the measured one; measured number inside the range.
By their numbers in this assay, from the lowest: compounds 3, 2 and 4 (each within the scatter of the next); then compound 1.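

Methyl in place of hydrogen on an aromatic carbon gives a 1.7-fold higher number from compound 3 to compound 4 (0.24 log units; within the scatter), and 4-methylphenyl in place of cyclobutyl on the carbonyl carbon gives a 1.7-fold higher number from compound 2 to compound 4 (0.23 log units; within the scatter), so in this assay this position accepts the added methyl without a step beyond the scatter. With 4-methylphenyl in place of pentan-3-yl there is a 57-fold lower number from compound 1 to compound 4 (1.76 log units; beyond the scatter), which leaves compound 1 apart from the three compounds that carry a ring other than its open chain. No measurement shown here accounts for the separation of pentan-3-yl from these ring groups.

On these data alone, it remains open whether an amine or a carboxylic acid in place of the methyl of compound 4 would stay with compounds 2, 3 and 4. Also open, as far as these compounds go, is whether an isopropyl or a tert-butyl group on the carbonyl carbon would fall with compound 1 or with those three.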